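Piperidinyl Replaces Diisopropylamino on a Nucleoside Core

This account rests on a few compounds, and the source may have more. Where it says the series, first, only, none or still open, it means among the compounds named here.

The measured compounds:
compound 1 `OC[C@H]1O[C@@H](n2cnc3c(COc4ccccn4)ncnc32)[C@H](O)[C@@H]1O`, 12000 nM
compound 2 `CN(Cc1ccccc1)Cc1ncnc2c1ncn2[C@@H]1O[C@H](CO)[C@@H](O)[C@H]1O`, 5600 nM
compound 3 `CC(C)N(Cc1ncnc2c1ncn2[C@@H]1O[C@H](CO)[C@@H](O)[C@H]1O)C(C)C`, 13000 nM

In a functional assay on HL-60 cells (Homo sapiens) for inhibition, with a stated time of 72 h (a higher number here means a weaker inhibitor, a lower number a stronger inhibitor), compound 3 gives the highest of the three numbers; it is separated from compound 1 only within the scatter, and from compound 2 by a 2.3-fold higher number from compound 2 to compound 3 (0.37 log units; beyond the scatter). Compound 4 `OC[C@H]1O[C@@H](n2cnc3c(CN4CCCCC4)ncnc32)[C@H](O)[C@@H]1O` differs from compound 3 in one place: piperidin-1-yl in place of diisopropylamino on a saturated chain carbon bound to an aromatic carbon. Among the compounds with values here, the only step that touches the same place and keeps a tertiary amine is a 2.3-fold higher number from compound 2 to compound 3 (0.37 log units; beyond the scatter), a modest one; the step of a 1.1-fold higher number from compound 1 to compound 3 (0.03 log units; within the scatter) lies within the scatter. Since the entering group is again a tertiary amine, compound 4 is expected to stay close to compound 3, with an estimated step of a 1.4-fold lower number from compound 3 to compound 4 (0.16 log units; within the scatter), perhaps slightly lower. Compound 4 is therefore estimated at 9000 nM, within 4000 nM to 20000 nM.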

Compound 4, half-maximal inhibitory concentration: 6900 nM
The estimate for compound 4 lay 1.3-fold (0.12 log units) above the measured number; the range from low to high includes it.
By their numbers in this assay, from the lowest: compounds 2, 4, 1 and 3 (each within the scatter of the next, the first and the last beyond it).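

In this assay, piperidin-1-yl on this saturated chain carbon bound to an aromatic carbon stays within the scatter of each earlier group (a 1.9-fold lower number from compound 3 to compound 4 (0.28 log units; within the scatter)) (a 1.2-fold higher number from compound 2 to compound 4 (0.09 log units; within the scatter)) (a 1.7-fold lower number from compound 1 to compound 4 (0.24 log units; within the scatter)). The only tertiary amine here with a six-membered non-aromatic ring therefore does not stand apart from diisopropylamino or benzyl(methyl)amino, although those two differ modestly from each other. Nothing available explains these numbers. Going by these compounds, it remains open whether morpholin-4-yl or dimethylamino on this carbon would give a number beyond the scatter of compound 4.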